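This account rests on a few compounds, and the source may have more. Where it says the series, first, only, none or still open, it means among the compounds named here.

Measured so far in a functional assay on HL-60 cells (Homo sapiens) for inhibition; on this read-out higher numbers stand for weaker inhibition and lower numbers for stronger inhibition:
- compound 1 `COc1ccc(-c2cc(=O)n(CC3CC3)nc2-c2ccc(OC)cc2)cc1`: 1800 nM
- compound 2 `COc1ccc(-c2cc(=O)n(CC3CCCC3)nc2-c2ccc(OC)cc2)cc1`: 110 nM

Compound 2 holds the lower of the two numbers, at 110 nM, and so shows the stronger inhibition. Going by the values given here, the only measured step is a 16-fold lower number from compound 1 to compound 2 (1.21 log units; beyond the scatter). It places cyclopentyl in place of cyclopropyl on a saturated chain carbon bound to an aromatic nitrogen.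

The next compound is compound 3 `COc1ccc(-c2cc(=O)n(C3CCCC3)nc2-c2ccc(OC)cc2)cc1`, with cyclopentyl in place of cyclopentylmethyl on an aromatic nitrogen.

The measured step bears on this change only indirectly. It shows that this assay can respond strongly to a change at this nitrogen substituent, but there the ring changed while the chain carbon stayed. Among the compounds with values here, no measured pair keeps the ring and changes only its attachment, so the direction rests on little and the range has to stay wide.

A small move toward weaker inhibition is expected, and the estimated step is a 1.8-fold higher number from compound 2 to compound 3 (0.26 log units; within the scatter). For compound 3 the expected value is 200 nM, with an estimated range of 60 nM to 700 nM.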

Compound 3, half-maximal inhibitory concentration: 510 nM
Beside the measured number, compound 3's estimate is 2.6-fold (0.41 log units) below it, and the stated range covers the measured number.
By their numbers in this assay, from the lowest: compound 2; then compound 3; then compound 1.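

In this assay the five-membered carbon ring alone does not set the level: with that ring kept, going from cyclopentylmethyl to cyclopentyl on the aromatic nitrogen gives a 4.6-fold higher number from compound 2 to compound 3 (0.67 log units; beyond the scatter) and so shows that the attachment of the ring matters as well as its identity. The directly attached cyclopentyl nevertheless keeps an edge over cyclopropylmethyl, with a 3.5-fold lower number from compound 1 to compound 3 (0.55 log units; beyond the scatter) and so places compound 3 between the other two compounds, although this comparison changes the ring and the attachment together and cannot separate the two. No measured information on hand explains why these changes at the nitrogen substituent shift the read-out.

Still open, as far as these compounds go, is whether a longer chain, such as cyclopentylethyl, would lower the number further than cyclopentylmethyl does, and whether cyclohexylmethyl would continue the trend from cyclopropylmethyl to cyclopentylmethyl. Also open, from the compounds shown here alone, is how an amine or a carboxylic acid on this substituent would read in this assay and whether either 4-methoxyphenyl group can be replaced without loss.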